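The source may report more compounds than this note shows. Statements on the series, on what has been measured and on what is new or still open speak of the compounds shown alone.

Measured so far:
- compound 1, `NCc1cc(Oc2cccc(C(=O)N3CC[C@@H](N)C3)c2)nc(C(F)(F)F)c1`: 670 nM
- compound 2, `NCc1cc(Oc2cccc(C(=O)NCc3cc4ccccc4s3)c2)nc(C(F)(F)F)c1`: "not determined" (no result reported)
- compound 3, `NCc1cc(Oc2cccc(C(=O)NC[C@@H](O)CO)c2)nc(C(F)(F)F)c1`: 2770 nM

In an ADME assay on the whole organism (plasma, Mus musculus) for pharmacokinetics, read by LC-MS, at a dose of 30 mg/kg by the oral route (on this read-out higher numbers stand for higher exposure at the dose given and lower numbers for lower exposure), compound 3 gives 2770 nM, the higher of the two numbers available; the nearest is compound 1, which gives 670 nM. For compound 2 the result in this assay is "not determined" (no result reported), so it adds no number to the picture. Among the compounds with values here, the one step that can be read is a 4.1-fold higher number from compound 1 to compound 3 (0.62 log units; beyond the scatter), a modest but real move that comes with a change of the group on the carbonyl carbon.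

Compound 4, `NCc1cc(Oc2cccc(C(=O)Nc3ccccc3)c2)nc(C(F)(F)F)c1`, is the next case. Its structure differs from compound 3 as follows: phenyl in place of 2,3-dihydroxypropyl on an amide-type nitrogen. This is again a change on the amide side of the shared core, the same side that moved in the step from compound 1 to compound 3, so a step of comparable size seems possible, but the direction cannot be read from that step alone, as neither of the measured groups is the phenyl that enters. On that basis compound 4 is expected to give 1200 nM, with a range from 300 nM to 5000 nM, meaning an estimated step of a 2.3-fold lower number from compound 3 to compound 4 (0.36 log units; beyond the scatter).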

Compound 4, maximal plasma concentration: 860 nM
Compound 4: middle estimate off by 1.4-fold (0.14 log units), on the high side; the measured number falls inside the stated range.
By their numbers in this assay, from the lowest: compounds 1 and 4 (each within the scatter of the next); then compound 3.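

In this assay, replacing 2,3-dihydroxypropyl with phenyl on the amide-type nitrogen gives a clear drop (a 3.2-fold lower number from compound 3 to compound 4 (0.51 log units; beyond the scatter)), so the higher number of compound 3 does not extend to every group at this place. Anilino and 3-aminopyrrolidin-1-yl on the carbonyl carbon cannot be told apart (a 1.3-fold higher number from compound 1 to compound 4 (0.11 log units; within the scatter)), which leaves compound 3 alone at the top of the three numbers now available. No measurement here accounts for these differences.

The compounds shown leave open whether a simple hydroxyethyl chain or a carboxylic acid at this place would stay with compound 3 or fall back to the level of compound 4. They also leave open whether a cyclohexyl ring would read like the phenyl, and whether the opposite stereocentre of the 2,3-dihydroxypropyl group would change the number.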